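The source may hold more compounds than are shown below. What is called first, only, known or untested is meant among the compounds shown, and "the series" means these compounds.

Compound 1 `CC(C)NCc1nnc(-c2ccccc2-c2ccccc2)s1` is the reference point. Among the compounds with values here, in a functional assay on the whole organism with Mus musculus as the target (a higher number here means that more compound is needed for the effect, a lower number that less compound is needed), compound 1 gives 23 mg/kg, the only plain number among the three compounds measured here. Compound 2 `CNCc1nnc(-c2ccccc2)s1` reaches only the limit of this assay, > 200 mg/kg. Compound 3 `Cc1ccccc1NCc1nnc(-c2ccccc2-c2ccccc2)s1` also stops at the limit, > 200 mg/kg. Within the data shown here, the single one-place step available, an at least 8.6-fold higher number from compound 1 to compound 3 (0.93 log units; beyond the scatter), shows that changing the group on the amine nitrogen can push the required dose past (the limit of > 200 mg/kg in this assay, at which 2 of the 3 values shown sit). Compound 4 `CC(N)c1nnc(-c2ccccc2-c2ccccc2)s1` changes the same end of the molecule more modestly: 1-aminoethyl in place of (isopropylamino)methyl on an aromatic carbon. Because the step of an at least 8.6-fold higher number from compound 1 to compound 3 (0.93 log units; beyond the scatter) went beyond the scatter, a rise is expected for compound 4 as well, estimated as a 2.6-fold higher number from compound 1 to compound 4 (0.42 log units; beyond the scatter). Compound 4 is therefore estimated at 60 mg/kg, expected between 20 mg/kg and 200 mg/kg.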

Compound 4, dose for half-maximal effect: 21 mg/kg
Compound 4: the middle estimate sits 2.9-fold (0.46 log units) above what was measured; low and high end bracket the measured number.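

In this assay, the smaller group does as well as the larger one: a 1.1-fold lower number from compound 1 to compound 4 (0.04 log units; within the scatter). The isopropyl end is therefore not required at this position, so a change to the group here need not raise the dose, as the 2-methylphenyl group of compound 3 did. Nothing measured here gives a reason why 1-aminoethyl and (isopropylamino)methyl behave alike.

The compounds shown leave open whether the amine nitrogen is needed at all, which a hydroxymethyl or ethyl group in its place would test. On these data alone, how a longer chain, such as 3-aminopropyl, would behave also remains open.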